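Moving the Ring Nitrogen on a Benzimidazolone Side Chain

The source may report more compounds than this note shows. Statements on the series, on what has been measured and on what is new or still open speak of the compounds shown alone.

Compound 1 `N#CCn1c(=O)n(-c2ccc(C#N)c(C(F)(F)F)c2)c2ccccc21` carries a nitrile on a saturated chain carbon bound to an aromatic nitrogen; in a physicochemical assay for solubility (on this read-out higher numbers stand for higher solubility and lower numbers for lower solubility), compound 1 gives 18900 nM. Compound 2 `N#Cc1ccc(-n2c(=O)n(Cc3cccnc3)c3ccccc32)cc1C(F)(F)F` replaces that nitrile with a pyridin-3-yl group, and in this assay compound 2 gives 2500 nM, the lower of the two numbers, with a 7.6-fold lower number from compound 1 to compound 2 (0.88 log units; beyond the scatter). Compound 3 `N#Cc1ccc(-n2c(=O)n(Cc3ccccn3)c3ccccc32)cc1C(F)(F)F` differs from compound 2 only by pyridin-2-yl in place of pyridin-3-yl on a saturated chain carbon bound to an aromatic nitrogen. No measured step tests this kind of change: the single step shown swaps a nitrile for a pyridine ring, which is a different alteration. Since both compounds hold the same atoms joined differently, the expectation for compound 3 is a step of a 1.2-fold higher number from compound 2 to compound 3 (0.08 log units; within the scatter), meaning none beyond the scatter. Compound 3 is therefore estimated at 3000 nM in this assay, within a range of 1000 nM to 9000 nM.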

Compound 3, solubility: 12000 nM
Estimate against measurement, compound 3: 4.0-fold (0.60 log units) below; measured number outside the range, above it.
By their numbers in this assay, from the lowest: compound 2; then compounds 3 and 1 (each within the scatter of the next).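

In this assay, this place on a saturated chain carbon bound to an aromatic nitrogen responds to how the pyridine ring is attached, not only to whether a ring is present: with the same atoms joined differently, pyridin-2-yl in place of pyridin-3-yl gives a 4.8-fold higher number from compound 2 to compound 3 (0.68 log units; beyond the scatter) on this read-out. The earlier pair showed only a nitrile giving way to pyridin-3-yl, so its lower number could have held for any pyridine ring; yet pyridin-2-yl in place of the nitrile gives a 1.6-fold lower number from compound 1 to compound 3 (0.20 log units; within the scatter), so these two groups are not told apart here. No measurement offered here explains the gap between the two pyridine groups. From the compounds shown here alone, whether a pyridin-4-yl group at this place would read like compound 2 or like compound 3 stays open. So does the outcome for a longer chain carrying the pyridin-2-yl ring, or for a simple amine at this place.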